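The compounds below may be only part of what the source reports. "The series", "measured", "known", "first", "only" and "open" are said of these compounds alone.

Of the compounds shown here, three built on a shared core have been measured in a functional assay on HeLa cells (Homo sapiens) for cytotoxicity, read by WST assay, with a stated time of 48 h; on this read-out higher numbers stand for weaker inhibition and lower numbers for stronger inhibition. Compound 1 `COc1ccc(CCC[C@H]2C[C@@H]([C@@H](O)c3ccc(OC)c(OC)c3)CO[C@@H]2c2ccc(OC)c(OC)c2)cc1OC` gives 37700 nM. Among the compounds with values here, compound 2 `COc1ccc(/C=C/C[C@H]2C[C@@H]([C@@H](O)c3ccc(OC)c(OC)c3)CO[C@@H]2c2ccc(OC)c(OC)c2)cc1` gives 12200 nM, and the single change between them, 2-(4-methoxyphenyl)ethenyl in place of 2-(3,4-dimethoxyphenyl)ethyl on a saturated chain carbon bound to a saturated ring carbon, brought a 3.1-fold lower number from compound 1 to compound 2 (0.49 log units; beyond the scatter). Compound 3 `C=CC[C@H]1C[C@@H]([C@@H](O)c2ccccc2)CO[C@@H]1c1ccccc1` carries plain phenyl rings on the core and a short allyl chain, and in this assay compound 3 gives 25400 nM. It stands second highest of the three numbers, close to compound 1 and apart from compound 2, whose number is lower beyond the scatter.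

Compound 4 `O[C@@H](c1ccccc1)[C@H]1CO[C@H](c2ccccc2)[C@@H](C/C=C/c2ccc(F)cc2)C1` differs from compound 3 in one place: 2-(4-fluorophenyl)ethenyl in place of vinyl on a saturated chain carbon bound to a saturated ring carbon. Within the data shown here, no measured pair shows exactly this change. The step from compound 1 to compound 2 is the nearest guide. It also ends in an aryl ring joined to the chain through a double bond, and it was modest in size and downward. On that basis the number for compound 4 is expected to fall modestly, by a step of a 2.1-fold lower number from compound 3 to compound 4 (0.33 log units; beyond the scatter). Compound 4 is therefore estimated at 12000 nM, with a range from 5000 nM to 30000 nM.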

Compound 4, half-maximal inhibitory concentration: 8340 nM
Estimate against measurement, compound 4: 1.4-fold (0.16 log units) above, and the stated range covers the measured number.
By their numbers in this assay, from the lowest: compounds 4 and 2 (each within the scatter of the next); then compounds 3 and 1 (each within the scatter of the next).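

In this assay, a ring-bearing chain at this position gave a lower number than the short chain it replaced: going from allyl to 3-(4-fluorophenyl)prop-2-en-1-yl on the core with plain phenyl rings brought a 3.0-fold lower number from compound 3 to compound 4 (0.48 log units; beyond the scatter). Within the data shown here, the earlier step, a 3.1-fold lower number from compound 1 to compound 2 (0.49 log units; beyond the scatter), only exchanged one aryl-ended chain for another on the methoxy-bearing core, so this is the first pair to set a chain with a terminal aromatic ring against one without, and the downward direction now appears on both versions of the core. Nothing available bears on why the number falls with this change.

The compounds shown leave open which part of the new chain accounts for the step, since the 4-fluorophenyl ring, its fluorine and the chain length all enter together, and a plain phenyl end or a chlorine in place of the fluorine would separate them. Also open, going by these compounds, is how this position responds to a saturated 3-(4-fluorophenyl)propyl chain, or to a chain ending in an amine or a carboxylic acid.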